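The compounds below may be only part of what the source reports. "The series", "measured", "known", "first", "only" and "open" are said of these compounds alone.

Three compounds have numbers in an assay on CHO cells for displacement of a labelled ligand from adenosine receptor A1 (Homo sapiens), read by scintillation counting, with a stated time of 3 h (on this read-out higher numbers stand for weaker inhibition and lower numbers for stronger inhibition), and one of them is only a limit. Compound 1 `Cc1ccc(Nc2nc3c(N4CCCC4)ncnc3s2)cc1` carries a 4-methylphenyl group on a core that differs from the others; in this assay compound 1 reaches only the limit of the assay, > 100000 nM, a result described by the limit of > 100000 nM in this assay, at which 1 of the 3 values shown sits. Compound 2 `OC[C@@H]1CCCN1c1ncnc2sc(Nc3ccc(Cl)cc3)nc12` gives 629 nM in this assay. Compound 3 `OC[C@@H]1CCCN1c1ncnc2sc(Nc3cccc(Br)c3)nc12` gives 530 nM in this assay, and the change a 1.2-fold lower number from compound 2 to compound 3 (0.07 log units; within the scatter) is within the scatter, so compound 2 and compound 3 cannot be told apart on these numbers.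

Compound 4 `Cc1ccc(Nc2nc3c(N4CCC[C@H]4CO)ncnc3s2)cc1` arises from compound 3 by 4-methylphenyl in place of 3-bromophenyl on a nitrogen on an aromatic ring. For the measured compounds named here, no measured step tracks this kind of exchange directly; the only measured step, from one halogenated phenyl to another, was within the scatter. Yet the 4-methylphenyl group appears on compound 1, whose value is only a limit, and that points towards a weaker result. Compound 4 is therefore expected to give about 3000 nM in this assay, with a range from 500 nM to 30000 nM. The expected step is a 5.7-fold higher number from compound 3 to compound 4 (0.75 log units; beyond the scatter).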

Compound 4, inhibition constant: 399 nM
Estimate against measurement, compound 4: 7.5-fold (0.88 log units) above, outside the stated range (below it).
By their numbers in this assay, from the lowest: compounds 4, 3 and 2 (each within the scatter of the next). At a limit, above all of these: compound 1.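

With 4-methylphenyl in place of 3-bromophenyl on a nitrogen on an aromatic ring, this assay shows a 1.3-fold lower number from compound 3 to compound 4 (0.12 log units; within the scatter), and methyl in place of chloro on an aromatic carbon gives a 1.6-fold lower number from compound 2 to compound 4 (0.20 log units; within the scatter), so among compounds 2, 3 and 4 these exchanges on the aromatic group cannot be told apart from the scatter. The 4-methylphenyl group therefore does not go with a weak result wherever it appears; the large step comes with hydroxymethyl in place of hydrogen on a saturated ring carbon, an at least 250-fold lower number from compound 1 to compound 4 (2.39 log units; beyond the scatter). The value of compound 1 is a limit and not a number: the limit of > 100000 nM in this assay, at which 1 of the 4 values shown sits.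

The compounds shown leave open whether hydroxymethyl is the only group that serves on that saturated ring carbon, or whether an amine, a carboxylic acid or a longer chain would give a similar number. They also leave open how a methoxy group or a nitrile on the aromatic group would read.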